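Moving a hydroxyl group in a compound with no readable potency

The source may hold more compounds than are shown below. What is called first, only, known or untested is meant among the compounds shown, and "the series" means these compounds.

In a functional assay on T47D cells (Homo sapiens) for antiproliferative activity, read by sulforhodamine B assay, with a stated time of 48 h (a higher number here means a weaker inhibitor, a lower number a stronger inhibitor), compound 1 (`CC1=C(CC/C(C)=C/CC/C(C)=C/C[C@@H](O)C2=CC(=O)OC2)C(C)(C)C(=O)CC1`) gives > 10000 nM, which is a limit of the assay and not a number. Compound 2 (`CC(=O)O[C@H](C/C=C(\C)CC/C=C(\C)CCC1=C(C)CCC(=O)C1(C)C)C1=CC(=O)OC1`), with acetyl in place of hydrogen on an oxygen on a saturated carbon, gives > 10000 nM, again a limit. This pair makes a step that the two limits leave unreadable from compound 1 to compound 2. The measured evidence so far amounts to the limit of > 10000 nM in this assay, at which 2 of the 2 values shown sit.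

Compound 3 (`CC1=C(CC/C(C)=C/CC/C(C)=C/CCC2=CC(=O)OC2O)C(C)(C)C(=O)CC1`) has the same atoms as compound 1, joined differently: a group of 8 heavy atoms (5 carbon, 3 oxygen; one five-membered non-aromatic ring with 1 hetero atom) in place of a group of 8 heavy atoms (5 carbon, 3 oxygen; one five-membered non-aromatic ring with 1 hetero atom), on a saturated chain carbon bound to a double-bonded chain carbon. Among the compounds with values here, the only measured step changes a different feature, and it has no readable size to carry over to this new change. The expectation therefore rests on very little, and another limit would be no surprise.

The expected change is an at least 1.2-fold lower number from compound 1 to compound 3 (0.09 log units; that floor lies within the scatter), an estimate that leans only modestly towards stronger inhibition. In this assay, the estimated value for compound 3 is 8000 nM, with an expected range from 2500 nM to 20000 nM.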

Compound 3, half-maximal inhibitory concentration: > 10000 nM
Compound 3 ended at the assay's limit (the forecaster's own chance of this, stated with the estimate: 50%); at least 1.2-fold (0.09 log units) between middle value and limit.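

Compound 3, like compound 1, ends at a limit of this assay and not at a number, so the step between compound 1 and compound 3 cannot be read. The compounds shown leave open whether either structural change affects potency at all, and the whole record so far is this: the limit of > 10000 nM in this assay, at which 3 of the 3 values shown sit.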